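This account rests on a few compounds, and the source may have more. Where it says the series, first, only, none or still open, it means among the compounds named here.

In a functional assay on HL-60 cells (Homo sapiens) for cytotoxicity, read by MTT assay, with a stated time of 48 h (on this read-out higher numbers stand for weaker inhibition and lower numbers for stronger inhibition), compound 2, `Fc1cccc(-c2nc(Nc3ccc(Br)cc3)c3cc(F)ccc3n2)c1`, gives > 50000 nM, which is a limit rather than a number. Its nearest measured relative is compound 1, `Fc1cccc(-c2nc(Nc3ccccc3F)c3cc(F)ccc3n2)c1`. In this assay compound 1 gives > 50000 nM, again a limit. The step between them, a step that the two limits leave unreadable from compound 1 to compound 2, therefore cannot be read. Compound 3, `Fc1cccc(-c2nc(Nc3ccccc3Br)c3cc(F)ccc3n2)c1`, has the same atoms as compound 2 joined differently: 2-bromophenyl in place of 4-bromophenyl on a nitrogen on an aromatic ring. Within the data shown here, the only measured step touching this nitrogen is the one just described, and both values shown sit at the same limit, as the limit of > 50000 nM in this assay, at which 2 of the 2 values shown sit, records, so no readable step gives a size or a direction for the step from compound 2 to compound 3. The value of compound 3 is expected to be 60000 nM, within 20000 nM to 200000 nM, most likely reported again as a limit. The expected step that the limit leaves unreadable from compound 2 to compound 3 is estimated as none beyond the scatter.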

Compound 3, half-maximal inhibitory concentration: > 50000 nM
Compound 3: no number, only a limit (the forecaster's own chance of this, stated with the estimate: 80%); the middle value lies beyond the limit too.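

In this assay compound 3 gives > 50000 nM, which is a limit and not a number. Among these compounds, no step among compound 1, compound 2 and compound 3 can be read. As far as these compounds go, how strongly any of these three compounds acts on the cells, and whether swapping or moving the halogen matters, remains open.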